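One Methyl Off a Nitrogen, Tried on a Second Core

A few compounds are considered here, and "the series" means these few. Any claim that something is new, unique, unknown or untested is made for them only; others in the source may bear on it.

Compound 1 `CN(C)c1ccc(/C=C/c2c(F)cccc2Cl)cc1` and compound 2 `CNc1ccc(/C=C/c2c(F)cccc2Cl)cc1` share a core and differ by a single change: hydrogen in place of methyl on a nitrogen on an aromatic ring. In a functional assay on LS174T cells (Homo sapiens) for antiproliferative activity (on this read-out higher numbers stand for weaker inhibition and lower numbers for stronger inhibition), compound 1 gives 19.2 nM, and compound 2 gives 7.6 nM. That step is a 2.5-fold lower number from compound 1 to compound 2 (0.40 log units; beyond the scatter).

Compound 3 `CN(C)c1ncc(/C=C/c2c(F)cccc2F)cn1` rests on a different core; the difference between the two cores is not broken down here. In this assay compound 3 gives only a limit, > 200 nM. Among the three values, (the limit of > 200 nM in this assay, at which 1 of the 3 values shown sits).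

Compound 4 `CNc1ncc(/C=C/c2c(F)cccc2F)cn1` carries the same change relative to compound 3: hydrogen in place of methyl on a nitrogen on an aromatic ring. The step from compound 3 to compound 4 is expected to be an at least 1.3-fold lower number from compound 3 to compound 4 (0.12 log units; that floor lies within the scatter), which rests on the step of a 2.5-fold lower number from compound 1 to compound 2 (0.40 log units; beyond the scatter). Compound 4 is therefore estimated at 150 nM, expected between 40 nM and 500 nM.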

Compound 4, half-maximal inhibitory concentration: > 200 nM
Compound 4 ended at the assay's limit; the forecaster's own chance of this, stated with the estimate: 45%; middle value at least 1.3-fold (0.12 log units) from the limit.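

Among the compounds shown here, no step between compound 3 and compound 4 can be read in this assay because each gives only a limit: the limit of > 200 nM in this assay, at which 2 of the 4 values shown sit.

From the compounds shown here alone, whether hydrogen in place of methyl lowers the number on this core, as it does from compound 1 to compound 2, stays open.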